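The source may report more compounds than this note shows. Statements on the series, on what has been measured and on what is new or still open speak of the compounds shown alone.

In an ADME assay on WI-38 cells (Homo sapiens) for cytotoxicity, read by MTT assay, with a stated time of 72 h (on this read-out higher numbers stand for weaker inhibition and lower numbers for stronger inhibition), compound 1 `O=C(CCc1cccc2c1B(O)OC2)Nc1nccs1` gives > 100000 nM, which is a limit of the assay and not a number. Compound 2 `O=C(CCc1cccc2c1B(O)OC2)Nc1ccc(F)cc1` reads 12000 nM and compound 3 `O=C(CCc1cccc2c1B(O)OC2)Nc1cccc(I)c1` reads 71000 nM, the higher of the two actual numbers. Compound 4 `O=C(CCc1cccc2c1B(O)OC2)Nc1cccc(-c2cccc(F)c2)c1` has 3-fluorophenyl in place of iodo on an aromatic carbon, (3-fluorophenyl in place of iodo on an aromatic carbon). Going by the values given here, no measured step changes this position, so the guides are loose: a 5.9-fold higher number from compound 2 to compound 3 (0.77 log units; beyond the scatter), an at least 8.3-fold lower number from compound 1 to compound 2 (0.92 log units; beyond the scatter) and an at least 1.4-fold lower number from compound 1 to compound 3 (0.14 log units; that floor lies within the scatter) all change the group on the amide-type nitrogen. With compound 3 at 71000 nM, a modest move to a lower number is expected in this assay. The expected step is a 2.8-fold lower number from compound 3 to compound 4 (0.45 log units; beyond the scatter). For compound 4, the estimate is 25000 nM, with an expected range of 6000 nM to 90000 nM.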

Compound 4, half-maximal inhibitory concentration: 37000 nM
Compound 4: middle estimate off by 1.5-fold (0.17 log units), on the low side, within the range that was stated.
By their numbers in this assay, from the lowest: compound 2; then compounds 4 and 3 (each within the scatter of the next). At a limit, above all of these: compound 1.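

Unlike the earlier steps, which swap the whole group on the amide-type nitrogen, this one keeps that ring and changes only what sits on its aromatic carbon. Replacing iodo, with 1 heavy atom, by 3-fluorophenyl, with 7, gives a 1.9-fold lower number from compound 3 to compound 4 (0.28 log units; within the scatter), so this added ring leaves the two compounds inseparable in this assay. Nothing given here accounts for this step. As far as these compounds go, whether an amine or a carboxylic acid at this position would move the number beyond the scatter remains open.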